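Amine swap on the shared core: compound 1 to compound 3

This account rests on a few compounds, and the source may have more. Where it says the series, first, only, none or still open, it means among the compounds named here.

Measured in an assay on isolated protein for binding affinity to corticotropin-releasing factor receptor 1 (Homo sapiens); a lower number here means a stronger inhibitor, a higher number a weaker inhibitor:
compound 1 `C=CCN(CC=C)c1nc(C)nc(Nc2c(CC)cccc2CC)n1`, 5700 nM
compound 2 `Cc1nc(NCc2ccc(C(F)(F)F)cc2)nc(Nc2c(C)cccc2C)n1`, > 10000 nM

For the measured compounds named here, compound 1 holds the only number in this set. Compound 2 sits at a limit of the assay, (the limit of > 10000 nM in this assay, at which 1 of the 2 values shown sits). Compound 3 `CCCN(CC1CC1)c1nc(C)nc(Nc2c(CC)cccc2CC)n1` is not yet measured; it differs from compound 1 by (cyclopropylmethyl)(propyl)amino in place of diallylamino on an aromatic carbon. Going by the values given here, no step between measured compounds is available, so the expectation rests on the change alone: a step from compound 1 to compound 3 of about a 1.9-fold lower number from compound 1 to compound 3 (0.28 log units; within the scatter) is expected, toward stronger binding but near the scatter. For compound 3 the estimate in this assay is 3000 nM, range 800 nM to 12000 nM.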

Compound 3, inhibition constant: > 10000 nM
Compound 3 gave a limit, no number; the forecaster's own chance of this, stated with the estimate: 15%; middle value at least 3.3-fold (0.52 log units) from the limit.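

At this position, on an aromatic carbon between two ring nitrogen atoms, (cyclopropylmethyl)(propyl)amino in place of diallylamino brings no gain in this assay: the step is an at least 1.7-fold higher number from compound 1 to compound 3 (0.24 log units; that floor lies within the scatter). Compound 3 gives a limit, not a number, so the full size of the step cannot be read. Compound 1 remains the only compound with a number in this assay: the limit of > 10000 nM in this assay, at which 2 of the 3 values shown sit.

Still open, from the compounds shown here alone, is whether a dipropylamino or bis(cyclopropylmethyl)amino group at this position would give a number in this assay. Also open, going by these compounds, is which of the two arms of the entering amine matters more.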